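The source may report more compounds than this note shows. Statements on the series, on what has been measured and on what is new or still open speak of the compounds shown alone.

Within the data shown here, in a functional assay on HepG2 cells (Homo sapiens) for antiproliferative activity, read by MTT assay, with a stated time of 48 h (a lower number here means a stronger inhibitor, a higher number a weaker inhibitor), compound 2 `COc1ccc(CN(C(=O)Cn2cc(COc3ccc4ccc(=O)oc4c3)nn2)c2cc(OC)c(OC)c(OC)c2)cc1` gives 1300 nM, the lowest number of the three measured so far. Compound 1 `COc1ccc(CN(C(=O)Cn2cc(COc3cc(=O)oc4ccccc34)nn2)c2cc(OC)c(OC)c(OC)c2)cc1` gives 6250 nM, and compound 3 `COc1ccc(CN(C(=O)Cn2cc(CSc3nc4ccccc4s3)nn2)c2cc(OC)c(OC)c(OC)c2)cc1` gives 49200 nM. Compound 4 `COc1ccc(CN(C(=O)Cn2cc(CSc3nc4ccccc4o3)nn2)c2cc(OC)c(OC)c(OC)c2)cc1` has not yet been measured, and its change is a group of 10 heavy atoms (7 carbon, 1 nitrogen, 1 oxygen, 1 sulfur; one five-membered aromatic ring with 2 hetero atoms, one six-membered aromatic ring of carbon only) in place of a group of 12 heavy atoms (9 carbon, 3 oxygen; one six-membered aromatic ring of carbon only, one six-membered aromatic ring with 1 hetero atom), on a saturated chain carbon bound to an aromatic carbon. The closest guide is a 38-fold higher number from compound 2 to compound 3 (1.58 log units; beyond the scatter), a large step, since the group entering there also has one five-membered aromatic ring with 2 hetero atoms and one six-membered aromatic ring of carbon only. The same kind of swap gave a 7.9-fold higher number from compound 1 to compound 3 (0.90 log units; beyond the scatter), a modest step in the same direction. A large rise in this assay is therefore expected, and the estimated step is a 19-fold higher number from compound 2 to compound 4 (1.28 log units; beyond the scatter). The estimated value for compound 4 is 25000 nM, with an expected range of 6000 nM to 80000 nM.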

Compound 4, half-maximal inhibitory concentration: 15600 nM
The estimate for compound 4 lay 1.6-fold (0.20 log units) above the measured number; measured number inside the range.
By their numbers in this assay, from the lowest: compound 2; then compound 1; then compound 4; then compound 3.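

In this assay the ring on the sulfur matters on its own: a 3.2-fold lower number from compound 3 to compound 4 (0.50 log units; beyond the scatter) comes with 1,3-benzoxazol-2-yl in place of 1,3-benzothiazol-2-yl, a change confined to that one group. Even so, a 12-fold higher number from compound 2 to compound 4 (1.08 log units; beyond the scatter) and a 2.5-fold higher number from compound 1 to compound 4 (0.40 log units; beyond the scatter) show that this gain does not reach the two compounds carrying oxygen on the chain. No measurement given here explains these differences.

Going by these compounds, those two steps change the linking atom and the ring system together, so the share of each stays open. Also open, on these data alone, is how an amine or a carboxylic acid in place of 1,3-benzoxazol-2-yl on the sulfur would read.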